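Swapping 1-benzothiophen-3-yl for phenyl at the assay limit

The source may hold more compounds than are shown below. What is called first, only, known or untested is meant among the compounds shown, and "the series" means these compounds.

Compound 1 `COc1c(OC(C)C)cc2occ(-c3csc4ccccc34)c(=O)c2c1OC(C)C` gives > 10000 nM
Compound 2 `COc1c(OC(C)C)cc2occ(-c3csc4ccccc34)c(=O)c2c1O` gives > 10000 nM
Compound 3 `CCOc1c(OC)cc2occ(-c3csc4ccccc34)c(=O)c2c1OC` gives 4000 nM

In a functional assay on MCF7 cells (Homo sapiens) for antiproliferative activity, read by sulforhodamine B assay, with a stated time of 72 h (on this read-out higher numbers stand for weaker inhibition and lower numbers for stronger inhibition), compound 1 gives > 10000 nM which is a limit and not a number. Compound 2 also stands at the limit of > 10000 nM in this assay, at which 2 of the 3 values shown sit, and so gives no number either. Compound 4 `COc1c(OC(C)C)cc2occ(-c3ccccc3)c(=O)c2c1OC(C)C` keeps the core of compound 1 and differs in one place. The change phenyl in place of 1-benzothiophen-3-yl on an aromatic carbon puts phenyl in place of 1-benzothiophen-3-yl on an aromatic carbon.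

Within the data shown here, the only measured step is a step that the two limits leave unreadable from compound 1 to compound 2 and it concerns a different change, hydrogen in place of isopropyl on an oxygen on an aromatic ring. It therefore offers no size to carry over. Among the measured compounds shown here, compound 3 gives a true number of 4000 nM in this assay but no measured pair shows what losing 1-benzothiophen-3-yl does. The expectation therefore starts from compound 1 at > 10000 nM and foresees no readable step in either direction. Compound 4 is estimated at 15000 nM with an expected range of 5000 nM to 40000 nM and will quite likely return only a limit. The expected change is a step that the limit leaves unreadable from compound 1 to compound 4 in this assay and it stays within what the limit can show.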

Compound 4, half-maximal inhibitory concentration: > 10000 nM
Compound 4: only a limit was reported; the forecaster's own chance of this, stated with the estimate: 80%; the middle value is on the limit's open side.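

Compound 1 and compound 4 both give only a limit in this assay, so the step from 1-benzothiophen-3-yl to phenyl cannot be read: the limit of > 10000 nM in this assay, at which 3 of the 4 values shown sit.

The compounds shown leave open whether either group gives the stronger inhibition, and what the same change would do on the core of compound 3, which gives a true number.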